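Trifluoromethoxy for trifluoromethyl on the benzylic aryl ring

This account rests on a few compounds, and the source may have more. Where it says the series, first, only, none or still open, it means among the compounds named here.

Compound 3 `O=C(O)CNC(=O)c1c(O)c2c(n(Cc3ccc(C(F)(F)F)cc3)c1=O)COC2` gives 3.6 nM in an assay on Sf9 cells for inhibition of prolyl hydroxylase EGLN2 (Homo sapiens), read by TR-FRET, with stated times of 30 min and 2 h; a lower number here means a stronger inhibitor, a higher number a weaker inhibitor. Among the three numbers this is the second highest; its nearest neighbour is compound 2 `O=C(O)CNC(=O)c1c(O)c2c(n(Cc3nc4ccccc4s3)c1=O)CCOC2` with 3.3 nM in this assay, and the furthest is compound 1 `O=C(O)CNC(=O)c1c(O)c2c(n(Cc3ccc(Cl)cc3)c1=O)CCOC2` with 5.9 nM in this assay, both gaps being within the scatter. Within the data shown here, the only step drawn so far, a 1.8-fold lower number from compound 1 to compound 2 (0.25 log units; within the scatter), exchanges the whole aryl group and lies within the scatter. Among the measured compounds shown here, compound 1 and compound 2 differ from compound 3 elsewhere in the structure as well, so no step is drawn from them to compound 3.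

Compound 4 `O=C(O)CNC(=O)c1c(O)c2c(n(Cc3ccc(OC(F)(F)F)cc3)c1=O)COC2` is compound 3 with trifluoromethoxy in place of trifluoromethyl on an aromatic carbon. For the measured compounds named here, no measured step exchanges a substituent on this aryl ring while keeping the rest, so the change rests on no direct precedent. Given that an exchange of the entire aryl group gave only a 1.8-fold lower number from compound 1 to compound 2 (0.25 log units; within the scatter), a para substituent swap is expected to stay within the scatter in this assay. Compound 4 is therefore expected at 4 nM in this assay, within 1.5 nM to 11 nM, the step being a 1.1-fold higher number from compound 3 to compound 4 (0.05 log units; within the scatter).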

Compound 4, half-maximal inhibitory concentration: 2.4 nM
For compound 4 the middle estimate is 1.7-fold (0.22 log units) above the measured one; the measured number falls inside the stated range.
By their numbers in this assay, from the lowest: compounds 4, 2, 3 and 1 (each within the scatter of the next, the first and the last beyond it).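

Among these compounds, this is the first measured exchange on the benzylic aryl ring with the rest of the structure kept, on an aromatic carbon para to a large group. In this assay the change gives a 1.5-fold lower number from compound 3 to compound 4 (0.18 log units; within the scatter), so at this position trifluoromethoxy and trifluoromethyl cannot be told apart, despite the extra heavy atom and the hydrogen-bond acceptor counted for trifluoromethoxy. No measurement at hand bears on why the two groups read alike.

Going by these compounds, whether an amine or a carboxylic acid on the same aromatic carbon would also stay within the scatter remains open. Also open, on these data alone, is whether trifluoromethoxy in place of trifluoromethyl gives a similarly small step on the core of compound 1, or whether the step depends on the shared core of compound 3 and compound 4.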